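A few compounds are considered here, and "the series" means these few. Any claim that something is new, unique, unknown or untested is made for them only; others in the source may bear on it.

All four compounds share one core, an ester-linked scaffold that carries an acetylsalicylate on one side and a varying ester group on the other. Compound 1 `CC(=O)Oc1ccccc1C(=O)O[C@H]1CO[C@H]2[C@@H]1OC[C@H]2OC(=O)c1snnc1C` gives 0.0065 h in an ADME assay on a cell-free system (plasma, Homo sapiens) for metabolic stability, with Plasma (Rattus norvegicus) as the target, read by HPLC, at pH 7.4; on this read-out higher numbers stand for a longer-lived compound and lower numbers for a shorter-lived compound. Compound 2 `CC(=O)Oc1ccccc1C(=O)O[C@H]1CO[C@H]2[C@@H]1OC[C@H]2OC(=O)c1ccnn1C` gives 0.0642 h in this assay, and compound 3 `CC(=O)Oc1ccccc1C(=O)O[C@H]1CO[C@H]2[C@@H]1OC[C@H]2OC(=O)c1cccc(C)c1` gives 0.0203 h in this assay. Among these three, compound 3 stands second highest: it sits between compound 1 and compound 2, with a 3.2-fold lower number from compound 2 to compound 3 (0.50 log units; beyond the scatter) and a 3.1-fold higher number from compound 1 to compound 3 (0.49 log units; beyond the scatter).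

Compound 4 `CC(=O)Oc1ccccc1C(=O)O[C@H]1CO[C@H]2[C@@H]1OC[C@H]2OC(=O)c1ccc(-c2ccccc2)cc1` differs from compound 3 in one place: 4-phenylphenyl in place of 3-methylphenyl on a carbonyl carbon. For the measured compounds named here, no measured step swaps one all-carbon aromatic ring for another; the steps that exist all exchange the whole group on that carbonyl carbon, and each of them was modest, as a 9.9-fold higher number from compound 1 to compound 2 (0.99 log units; beyond the scatter), a 3.1-fold higher number from compound 1 to compound 3 (0.49 log units; beyond the scatter) and a 3.2-fold lower number from compound 2 to compound 3 (0.50 log units; beyond the scatter) show. Because compound 3 gives 0.0203 h and the change from compound 3 to compound 4 again only reshapes that group, a modest step at most is expected in this assay, with no clear direction. Compound 4 is therefore estimated at 0.025 h, within 0.007 h to 0.08 h, which means an expected step of a 1.2-fold higher number from compound 3 to compound 4 (0.09 log units; within the scatter).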

Compound 4, half-life: > 0.333 h
Compound 4 was reported as a limit; the forecaster's own chance of this, stated with the estimate: 5%; middle value at least 13-fold (1.12 log units) from the limit.
By their numbers in this assay, from the lowest: compound 1; then compound 3; then compound 2. At a limit, above all of these: compound 4.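

The number for compound 4 in this assay is a limit, not an exact half-life: the limit of > 0.333 h in this assay, at which 1 of the 4 values shown sits.

With 4-phenylphenyl on the carbonyl carbon, the data show an at least 16-fold higher number from compound 3 to compound 4 (1.21 log units; beyond the scatter), an at least 5.1-fold higher number from compound 2 to compound 4 (0.71 log units; beyond the scatter) and an at least 51-fold higher number from compound 1 to compound 4 (1.70 log units; beyond the scatter). The earlier steps shown here at this carbonyl carbon were all modest, so this result shows that the group placed there can shift the half-life much further, and that exchanging one all-carbon aromatic group for another is enough to produce a large step.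

The compounds shown do not separate the effect of the second aromatic ring from that of the larger group as a whole. Nor do they show how the half-life would respond to a cyclohexyl group, or to a phenyl ring carrying an amine or a carboxylic acid, on the same carbonyl carbon.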